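Trifluoromethyl on the phenyl arm of compound 1

The compounds below may be only part of what the source reports. "The series", "measured", "known", "first", "only" and "open" are said of these compounds alone.

Measured so far:
compound 1 `c1ccc(-c2cn3ccnc3c(-c3ccc4ncn(C5CCCCC5)c4c3)n2)cc1` gives -11.1%
compound 2 `COc1ccc(-c2cn3ccnc3c(-c3ccc4ncn(C5CCCCC5)c4c3)n2)cc1` gives -8.6%
compound 3 `c1cn2cc(-c3ccsc3)nc(-c3ccc4ncn(C5CCCCC5)c4c3)c2n1` gives 63.7%

Compound 1 stands lowest of the three numbers in a functional assay on T47D cells (Homo sapiens) for inhibition, read by sulforhodamine B assay, with a stated time of 48 h, tested at 10 uM (on this read-out lower numbers stand for less inhibition and higher numbers for more inhibition at the one concentration tested (going by the name of the read-out)), though its nearest neighbour, compound 2, lies within the scatter of it, so no order between those two can be read. Compound 3 sits far above both.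

Compound 4 `FC(F)(F)c1cccc(-c2cn3ccnc3c(-c3ccc4ncn(C5CCCCC5)c4c3)n2)c1` differs from compound 1 in one place: trifluoromethyl in place of hydrogen on an aromatic carbon. The change sits on the six-membered aromatic ring of carbon only, the same ring that carries the methoxy in compound 2.

For the measured compounds named here, only one measured step bears directly on this: a number 2.5 percentage points higher from compound 1 to compound 2 (within the scatter), a substituent added to the same ring with no shift beyond the scatter. The large steps of a number 74.8 percentage points higher from compound 1 to compound 3 (beyond the scatter) and a number 72.3 percentage points higher from compound 2 to compound 3 (beyond the scatter) replace the whole ring and so say little about a substituent on it. A small step, within the scatter, is therefore expected for compound 4, a number 8.1 percentage points higher from compound 1 to compound 4 (within the scatter). Compound 4 is estimated at -3%, range -25% to 25%.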

Compound 4, a percentage reported as inhibition, at one concentration (the size of the read-out at that concentration, not a potency): 52.2%
Compound 4: middle estimate off by 55.2 percentage points, on the low side, and the stated range ends below it.
By their numbers in this assay, from the lowest: compounds 1 and 2 (each within the scatter of the next); then compound 4; then compound 3.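

In this assay, the phenyl arm of compound 1 proves sensitive to substitution: with a number 63.3 percentage points higher from compound 1 to compound 4 (beyond the scatter), one added group moves the number far beyond the scatter, which the methoxy of compound 2 did not do. The 3-(trifluoromethyl)phenyl arm also separates clearly from the 4-methoxyphenyl arm, with a number 60.8 percentage points higher from compound 2 to compound 4 (beyond the scatter), while the thiophen-3-yl arm stays modestly ahead of it, with a number 11.5 percentage points lower from compound 3 to compound 4 (beyond the scatter), so a phenyl arm is not tied to a low number. Nothing available accounts for this rise.

Still open, going by these compounds, is whether the rise goes with trifluoromethyl itself or with its place meta to a large group, since compound 2 carries its methoxy as a 4-methoxyphenyl arm. Also open, on these data alone, is whether an amine or a carboxylic acid at that same place would follow trifluoromethyl or methoxy.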